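This account rests on a few compounds, and the source may have more. Where it says the series, first, only, none or still open, it means among the compounds named here.

Measured compounds in a functional assay on SK-HEP1 cells (Homo sapiens) for inhibition, read by sulforhodamine B assay, with a stated time of 48 h; on this read-out higher numbers stand for weaker inhibition and lower numbers for stronger inhibition:
Compound 1, `O=C(Nc1ccc2c(c1)CCCN2c1ccc(C(=O)NO)cc1)Nc1ccc(Cl)c(C(F)(F)F)c1`, gives 3400 nM.
Compound 2, `O=C(CCCCCC(=O)Nc1ccc(NC(=O)Nc2ccc(Cl)c(C(F)(F)F)c2)cc1)NO`, gives only a limit, > 10000 nM.
Compound 3, `O=C(/C=C/c1ccc(CN2CCc3cc(NC(=O)Nc4ccc(Cl)c(C(F)(F)F)c4)ccc32)cc1)NO`, gives 3500 nM.

Compound 2 stands at the edge of what this assay reports: its result is a limit and not a number, and (the limit of > 10000 nM in this assay, at which 1 of the 3 values shown sits). Compound 1 and compound 3 lie within the usual scatter of each other, so no order can be drawn between them; compound 2 is the only one of the three for which the assay gave no number at all.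

The next compound, compound 4, `O=C(CCCCC(=O)Nc1ccc(NC(=O)Nc2ccc(Cl)c(C(F)(F)F)c2)cc1)NO`, is reached from compound 2 by a single change in the chain that carries the hydroxycarbamoyl group: hydroxycarbamoyl in place of (hydroxycarbamoyl)methyl on a saturated chain carbon, four bonds along the chain from a carbonyl carbon. The rest of the molecule, the urea and the aryl ring bearing chlorine and trifluoromethyl, is kept unchanged.

Within the data shown here, since compound 2 has only a limit, no measured step starting from it is known, and the size of the change on this assay cannot be read from the data. Shortening the chain by one saturated carbon is a small alteration, and the expectation is that compound 4 stays near the limit, with the step that the limit leaves unreadable from compound 2 to compound 4 taken as no change beyond the scatter. Compound 4 is therefore estimated at 12000 nM, with a range from 4000 nM to 40000 nM, and a fair chance that the assay again reports only a limit.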

Compound 4, half-maximal inhibitory concentration: > 10000 nM
Compound 4 gave a limit, no number (the forecaster's own chance of this, stated with the estimate: 60%); the middle value lies beyond the limit too.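

Compound 2 and compound 4 both gave only a limit in this assay, not a number, so the step between them cannot be read: the limit of > 10000 nM in this assay, at which 2 of the 4 values shown sit.

The compounds shown leave open whether hydroxycarbamoyl in place of (hydroxycarbamoyl)methyl on the saturated chain changes inhibition at all.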